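Swapping the Ring-Nitrogen Substituent: What to Expect

The source may hold more compounds than are shown below. What is called first, only, known or untested is meant among the compounds shown, and "the series" means these compounds.

Compound 1 `COc1ccc(-c2cnc3nc(N)nc(N4CCN(c5cc(Cl)cc(Cl)c5)CC4)c3n2)cc1OC` was tested in a functional assay on cells (T-cell, Homo sapiens) for inhibition (on this read-out higher numbers stand for weaker inhibition and lower numbers for stronger inhibition), and gave 3400 nM. Of the two numbers in hand, this is the higher one. The comparison compound, compound 2 `COc1ccc(-c2cnc3nc(N)nc(OC(C)C)c3n2)cc1OC`, carries a different group on the shared core, and in this assay compound 2 gives 400 nM; the gap between the two values lies beyond the usual scatter, so compound 1 is the weaker inhibitor of the pair.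

Compound 3 `COc1ccc(-c2cnc3nc(N)nc(N4CCN(Cc5ccc(C(C)(C)C)cc5)CC4)c3n2)cc1OC` keeps the shared core of compound 1 and differs from it in one place: 4-(tert-butyl)benzyl in place of 3,5-dichlorophenyl on an amine nitrogen in a ring. Among the compounds with values here, no measured pair shows what this kind of change does on this core, so any expectation rests on compound 1 alone and on the fact that compound 2 shows a lower number with a quite different group there. With so little to go on, the expected step of a 1.7-fold lower number from compound 1 to compound 3 (0.23 log units; within the scatter) is a small one, towards a somewhat lower number, and it may well fall within the scatter. Compound 3 is therefore expected to give about 2000 nM in this assay, within a range from 400 nM to 10000 nM.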

Compound 3, half-maximal inhibitory concentration: 4300 nM
The estimate for compound 3 lay 2.2-fold (0.33 log units) below the measured number; low and high end bracket the measured number.
By their numbers in this assay, from the lowest: compound 2; then compounds 1 and 3 (each within the scatter of the next).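

In this assay, putting 4-(tert-butyl)benzyl in place of 3,5-dichlorophenyl on the amine nitrogen of the six-membered ring gives a 1.3-fold higher number from compound 1 to compound 3 (0.10 log units; within the scatter), so this read-out does not separate the two compounds. Within the data shown here, this is the first pair in which only the group on that nitrogen varies, and it shows that two quite different groups can sit there with no change beyond the usual scatter: one is a ring carrying two chlorine atoms, and the other is a ring of carbon only, joined through an extra carbon and carrying a tert-butyl group. Nothing available accounts for this flat result, so it stands as an observation only.

On these data alone, both groups are hydrocarbon-based aromatic rings, so it remains open whether a different kind of group on that nitrogen, such as a plain hydrogen, a methyl, or a short chain ending in an amine or a carboxylic acid, would move the number. Also open, as far as these compounds go, is whether any such group on this ring could bring the number close to that of compound 2, which gives 400 nM in this assay with a propan-2-yloxy group in place of the whole ring.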